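The source may report more compounds than this note shows. Statements on the series, on what has been measured and on what is new or still open speak of the compounds shown alone.

Compound 3 `COc1ccc(-c2ccc3c(NCCCNCc4cc(F)ccc4OC)ccnc3c2)cc1` belongs to a small set of analogues sharing one core. In a physicochemical assay for acid dissociation, compound 3 gives 9.47, level with compound 1 `COc1ccc(-c2ccc3c(NCCCNCc4cccc(OC)c4O)ccnc3c2)cc1` at 9.47 and compound 2 `COc1ccc(-c2ccc3c(NCCCNCc4ccco4)ccnc3c2)cc1` at 9.47. The change from compound 3 to compound 4 `COc1ccc(F)cc1CNCCCNc1ccnc2cc(-c3cccc4ccccc34)ccc12` is naphthalen-1-yl in place of 4-methoxyphenyl on an aromatic carbon. Among the compounds with values here, no measured step touches this position: the steps of no change at the digits printed from compound 1 to compound 3 (within the scatter) and no change at the digits printed from compound 2 to compound 3 (within the scatter) alter only the group on the saturated chain carbon bound to an amine nitrogen, and each stayed within the scatter. Compound 4 is therefore expected to show no step beyond the scatter, no change at the digits printed from compound 3 to compound 4 (within the scatter), with an estimated value of 9.47 and a range from 9.15 to 9.8.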

Compound 4, acid dissociation constant: 9.47
Compound 4: the middle estimate sits on the measured number at the digits printed, within the range that was stated.
By their numbers in this assay, from the lowest: compounds 1, 2, 3 and 4 (each within the scatter of the next).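

In this assay, within the data shown here, naphthalen-1-yl in place of 4-methoxyphenyl gives no change at the digits printed from compound 3 to compound 4 (within the scatter), the only measured step at this aromatic carbon; the earlier steps altered only the group on the saturated chain carbon bound to an amine nitrogen. The read-out therefore also stays within the scatter for a change at this second place, where the entering group has two six-membered aromatic rings of carbon only and no oxygen. Nothing available accounts for this result. The compounds shown leave open whether a carboxylic acid or an amine on this aromatic carbon would also stay within the scatter in this assay.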